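From 2-bromophenyl to 3-bromophenyl

The source may report more compounds than this note shows. Statements on the series, on what has been measured and on what is new or still open speak of the compounds shown alone.

Measured so far in a functional assay on B16 cells (Mus musculus) for antiproliferative activity, with a stated time of 72 h; a lower number here means a stronger inhibitor, a higher number a weaker inhibitor:
Compound 1 `OC[C@H]1O[C@@H](n2cnc3c(NCc4cccc(F)c4)ncnc32)[C@H](O)[C@@H]1O`: "not determined" (no result reported)
Compound 2 `OC[C@H]1O[C@@H](n2cnc3c(NCc4ccc(F)cc4)ncnc32)[C@H](O)[C@@H]1O`: "not determined" (no result reported)
Compound 3 `OC[C@H]1O[C@@H](n2cnc3c(NCc4ccccc4Br)ncnc32)[C@H](O)[C@@H]1O`: > 166000 nM

Only compound 3 has a reported outcome in this assay, and compound 3 stands at > 166000 nM, which is a limit and not a number. Among the compounds with values here, compound 1 and compound 2 offer no result for comparison, so no measured step shows how a change on the shared core moves the read-out.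

The next compound is compound 4 `OC[C@H]1O[C@@H](n2cnc3c(NCc4cccc(Br)c4)ncnc32)[C@H](O)[C@@H]1O`, which carries 3-bromophenyl in place of 2-bromophenyl on a saturated chain carbon bound to a nitrogen on an aromatic ring. With compound 3 at > 166000 nM, an expected change can be read only toward a stronger inhibitor, and only a modest one is expected. The expected move is an at least 1.6-fold lower number from compound 3 to compound 4 (0.22 log units; that floor lies within the scatter). For compound 4 the estimated half-maximal inhibitory concentration is 100000 nM, with an expected range from 25000 nM to 250000 nM. A report of only a limit would not be a surprise.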

Compound 4, half-maximal inhibitory concentration: > 166000 nM
Compound 4 was reported as a limit (the forecaster's own chance of this, stated with the estimate: 55%); middle value at least 1.6-fold (0.22 log units) away from the limit.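

Within the data shown here, compound 3 and compound 4 both give only a limit in this assay, so no step from 2-bromophenyl to 3-bromophenyl can be read from them: the limit of > 166000 nM in this assay, at which 2 of the 4 values shown sit.

As far as these compounds go, whether any group on the shared core gives a numerical half-maximal inhibitory concentration in these cells stays open.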